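Aniline exchange on the shared core: compound 3 to compound 4

This account rests on a few compounds, and the source may have more. Where it says the series, first, only, none or still open, it means among the compounds named here.

Measured so far in a functional assay on HeLa cells (Homo sapiens) for antiproliferative activity, read by MTT assay, with a stated time of 48 h; a lower number here means a stronger inhibitor, a higher number a weaker inhibitor:
compound 1 `O=C(/C=C/c1ccccc1)Nc1cc2ncnc(Nc3cc(Cl)cc(Cl)c3)c2s1` gives 3210 nM
compound 2 `O=C(/C=C/c1ccc(O)cc1)Nc1cc2c(Nc3ccc(Cl)c(Cl)c3)ncnc2s1` gives 24800 nM
compound 3 `O=C(/C=C/c1ccccc1)Nc1cc2c(Nc3ccc(F)c(Cl)c3)ncnc2s1` gives 2140 nM

Compound 3 has the lowest of the three numbers, but its gap to compound 1 lies within the scatter, so the two cannot be ordered against each other. Only compound 2 stands clearly apart, with the highest number of the set.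

Compound 4 `O=C(/C=C/c1ccccc1)Nc1cc2c(Nc3cc(Cl)cc(Cl)c3)ncnc2s1` is not yet measured. It differs from compound 3 in one place: 3,5-dichlorophenyl in place of 3-chloro-4-fluorophenyl on a nitrogen on an aromatic ring. Among the compounds with values here, no measured pair isolates this exchange on the same core, so no computed step exists for it. What can be said is indirect: compound 1 carries the same 3,5-dichlorophenyl on a differently arranged core, and the numbers of compound 1 at 3210 nM and of compound 3 at 2140 nM sit within the scatter of each other. The expected step is accordingly small, in no set direction, and probably not beyond the scatter: a 1.4-fold higher number from compound 3 to compound 4 (0.15 log units; within the scatter). Compound 4 is expected to give about 3000 nM in this assay. For compound 4 the expected range runs from 1200 nM to 8000 nM.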

Compound 4, half-maximal inhibitory concentration: 4 nM
Compound 4: middle estimate off by 750-fold (2.88 log units), on the high side; the whole stated range lies above it.
By their numbers in this assay, from the lowest: compound 4; then compounds 3 and 1 (each within the scatter of the next); then compound 2.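

In this assay, 3,5-dichlorophenyl in place of 3-chloro-4-fluorophenyl on the nitrogen gives a 540-fold lower number from compound 3 to compound 4 (2.73 log units; beyond the scatter), so this position responds very strongly to an exchange that leaves the heavy-atom, donor and acceptor counts unchanged. The 3,5-dichlorophenyl group does not carry this result independently of the core: compound 1, with the same group on a differently arranged core, gives 3210 nM, while compound 4 gives 4 nM. Nothing available accounts for the size of this step.

The compounds shown leave open whether the step depends on the second chlorine, the loss of fluorine, or both together. Also open, from the compounds shown here alone, is how 3-chlorophenyl, 3,5-difluorophenyl or 3,5-dimethylphenyl on the shared core would compare with compound 4.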